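Carbamate nitrogen substituents on a shared furanone core

The source may report more compounds than this note shows. Statements on the series, on what has been measured and on what is new or still open speak of the compounds shown alone.

Measured compounds:
compound 1 `C/C(=C\COC(=O)NC(C)(C)C)C1=CC(=O)C(C)(C)O1`, in a functional assay on L1210 cells (Mus musculus) for inhibition; a higher number here means a weaker inhibitor, a lower number a stronger inhibitor: 4.1 ug/mL
compound 2 `C=CCNC(=O)OC/C=C(\C)C1=CC(=O)C(C)(C)O1`, in this assay: 6.2 ug/mL
compound 3 `C/C(=C\COC(=O)NC1CCCCC1)C1=CC(=O)C(C)(C)O1`, in this assay: 3.7 ug/mL

All three share the same core and differ only in the group on the amide-type nitrogen of the carbamate. Compound 3 gives the lowest of the three numbers in this assay, but its nearest neighbour is compound 1, and the step of a 1.1-fold lower number from compound 1 to compound 3 (0.04 log units; within the scatter) lies within the scatter, as does a 1.7-fold lower number from compound 2 to compound 3 (0.22 log units; within the scatter); the third step, a 1.5-fold higher number from compound 1 to compound 2 (0.18 log units; within the scatter), is likewise within the scatter. Compound 3 therefore cannot be called the strongest inhibitor on these numbers.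

Compound 4 `C/C(=C\COC(=O)NCc1ccccc1)C1=CC(=O)C(C)(C)O1` is the next member of the set. The change from compound 3 is benzyl in place of cyclohexyl on an amide-type nitrogen. Among the measured compounds shown here, every measured step so far exchanges one group for another on this same nitrogen, and none of them has moved the number beyond the scatter. The swap to benzyl is therefore expected to follow the same pattern, with no step beyond the scatter in either direction: the estimated step is a 1.1-fold higher number from compound 3 to compound 4 (0.03 log units; within the scatter). For compound 4 the expected value in this assay is 4 ug/mL, with a range from 2 ug/mL to 8 ug/mL.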

Compound 4, half-maximal inhibitory concentration: 4.7 ug/mL
Beside the measured number, compound 4's estimate is 1.2-fold (0.07 log units) below it; measured number inside the range.
By their numbers in this assay, from the lowest: compounds 3, 1, 4 and 2 (each within the scatter of the next).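

Benzyl puts an aromatic ring on the amide-type nitrogen for the first time among these compounds, and in this assay the exchange for cyclohexyl gives only (a 1.3-fold higher number from compound 3 to compound 4 (0.10 log units; within the scatter)), so the six-membered aromatic ring of carbon only and its non-aromatic counterpart cannot be told apart here. The comparisons with the two open-chain groups read the same way: benzyl in place of tert-butyl gives (a 1.1-fold higher number from compound 1 to compound 4 (0.06 log units; within the scatter)), and phenyl in place of vinyl on a saturated chain carbon bound to an amide-type nitrogen gives (a 1.3-fold lower number from compound 2 to compound 4 (0.12 log units; within the scatter)), leaving all four groups on this nitrogen without a step beyond the scatter and none of them standing apart. Nothing in the information available accounts for this lack of separation.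

From the compounds shown here alone, whether an amine, a carboxylic acid or a longer chain on this nitrogen would move the number beyond the scatter remains open. So does the effect of a fluorine or a methoxy group on the benzyl ring, and of replacing the amide hydrogen with a methyl group.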